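Oxadiazole series: urea aryl swap on compound 2

The source may report more compounds than this note shows. Statements on the series, on what has been measured and on what is new or still open speak of the compounds shown alone.

Measured compounds in a functional assay on MDA-MB-231 cells (Homo sapiens) for antiproliferative activity, read by MTT assay, with a stated time of 72 h; on this read-out higher numbers stand for weaker inhibition and lower numbers for stronger inhibition:
compound 1 `O=C(Nc1cccc(-c2nc(-c3ccc(NC(=O)c4cccnc4)cc3Cl)no2)c1)c1ccccc1` gives 12800 nM;
compound 2 `O=C(Nc1cccc(-c2nc(-c3ccc(NC(=O)c4cccnc4)cc3Cl)no2)c1)Nc1ccc(Cl)c(C(F)(F)F)c1` gives 1900 nM.

Compound 2 holds the lowest number of the two in this assay. Among the compounds with values here, the only measured step, a 6.7-fold lower number from compound 1 to compound 2 (0.83 log units; beyond the scatter), follows the change from a benzamide to an aryl urea on the shared core and falls beyond the scatter. Compound 3 `CS(=O)(=O)Nc1cccc(NC(=O)Nc2cccc(-c3nc(-c4ccc(NC(=O)c5cccnc5)cc4Cl)no3)c2)c1` keeps the urea of compound 2 and differs in the aryl group on that urea: 3-(methanesulfonamido)phenyl in place of 4-chloro-3-(trifluoromethyl)phenyl on an amide-type nitrogen. Within the data shown here, no measured pair shows the effect of exchanging one aryl group for another on the urea nitrogen, so the step from compound 1 to compound 2 bears on compound 3 only in that the urea linkage is retained; it does not tell how the 3-(methanesulfonamido)phenyl group compares with the 4-chloro-3-(trifluoromethyl)phenyl group. Among the measured compounds shown here, with no direct precedent, the expected step of a 1.6-fold higher number from compound 2 to compound 3 (0.20 log units; within the scatter) in this assay is small and may well lie within the scatter, with a slight lean toward a higher number. On this basis compound 3 is estimated at 3000 nM, with a range from 900 nM to 10000 nM.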

Compound 3, half-maximal inhibitory concentration: > 10000 nM
Compound 3 ended at the assay's limit; the forecaster's own chance of this, stated with the estimate: 10%; at least 3.3-fold (0.52 log units) between middle value and limit.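

In this assay, compound 3 is recorded only as a limit and not as a number, so its step from compound 1 cannot be read: the limit of > 10000 nM in this assay, at which 1 of the 3 values shown sits.

The aryl group on the urea now has a measured effect of its own: 3-(methanesulfonamido)phenyl in place of 4-chloro-3-(trifluoromethyl)phenyl on an amide-type nitrogen gives an at least 5.2-fold higher number from compound 2 to compound 3 (0.72 log units; beyond the scatter). The urea linkage is present in both compounds, so it does not by itself keep the number at the level of compound 2, and a 6.7-fold lower number from compound 1 to compound 2 (0.83 log units; beyond the scatter) cannot be credited to the urea alone.

This single exchange removes the chlorine and the trifluoromethyl and adds the methanesulfonamido group all at once, leaving open which of these changes accounts for the step. Going by these compounds, a urea phenyl carrying only the chlorine or only the trifluoromethyl, or an amine or a carboxylic acid in place of the methanesulfonamido group, would begin to separate these contributions, and the true value of compound 3 remains open beyond its limit.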